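Adding a Fluorine to a Weak Coumarin Amine Inhibitor

The compounds below may be only part of what the source reports. "The series", "measured", "known", "first", "only" and "open" are said of these compounds alone.

Compound 2, with the structure `CN(C)Cc1cc(=O)oc2cc(OCc3ccccc3)ccc12`, was tested in an assay for inhibition of Amine oxidase [flavin-containing] B (Rattus norvegicus) (a higher number here means a weaker inhibitor, a lower number a stronger inhibitor), where compound 2 gives 1800 nM. For the measured compounds named here, that is the higher of the two numbers measured so far. Going by the values given here, the only other measured compound, compound 1 with the structure `NC(=O)Cc1cc(=O)oc2cc(OCc3cccc(F)c3)ccc12`, differs from compound 2 in two places at once, and in this assay compound 1 gives 50 nM; this gap is well beyond the usual scatter. Compound 3, with the structure `CN(C)Cc1cc(=O)oc2cc(OCc3cccc(F)c3)ccc12`, keeps the side chain of compound 2 and changes only the benzyl ring: fluoro in place of hydrogen on an aromatic carbon. Among the compounds with values here, with no measured pair that isolates this change, the expected step is modest, toward a lower number, and the step from compound 2 to compound 3 is estimated at a 2.6-fold lower number from compound 2 to compound 3 (0.41 log units; beyond the scatter). On that basis compound 3 is expected to give about 700 nM in this assay, within a range from 200 nM to 2500 nM.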

Compound 3, half-maximal inhibitory concentration: 510 nM
Estimate against measurement, compound 3: 1.4-fold (0.14 log units) above, and the stated range covers the measured number.
By their numbers in this assay, from the lowest: compound 1; then compound 3; then compound 2.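

In this assay, fluoro in place of hydrogen on an aromatic carbon of the benzyl ring, meta to a large group, gives a change beyond the scatter (a 3.5-fold lower number from compound 2 to compound 3 (0.55 log units; beyond the scatter)), so this one added atom counts on its own at this position. With the 3-fluorobenzyl group now shared, dimethylamino in place of carbamoyl on the side chain also stands alone, and it gives the large step (a 10-fold higher number from compound 1 to compound 3 (1.01 log units; beyond the scatter)) against the modest one for fluoro. No measurement here offers an explanation for either step.

As far as these compounds go, whether chloro or methoxy at this place would act as fluoro does remains open, as does the effect of fluoro on other carbons of the ring. From the compounds shown here alone, it is also open how a carboxylic acid or a longer chain would compare with carbamoyl and dimethylamino on the side chain.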